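The source may report more compounds than this note shows. Statements on the series, on what has been measured and on what is new or still open speak of the compounds shown alone.

Compound 1 `COc1cc(OC)c(-c2coc3cc(OCc4ccc(Br)cc4)ccc3c2=O)cc1OC`: 1050 nM
Compound 2 `COc1cc(OC)c(-c2coc3cc(OCc4ccccc4C#N)ccc3c2=O)cc1OC`: > 10000 nM
Compound 3 `COc1cc(OC)c(-c2coc3cc(OCc4cccc(Br)c4)ccc3c2=O)cc1OC`: 870 nM

These values come from a functional assay on HepG2 cells (Homo sapiens) for antiproliferative activity, read by MTT assay, with a stated time of 24 h; a higher number here means a weaker inhibitor, a lower number a stronger inhibitor. Compound 3 gives 870 nM, and compound 1 is its nearest neighbour on the numbers, with a 1.2-fold lower number from compound 1 to compound 3 (0.08 log units; within the scatter). That step lies within the scatter, so the two compounds cannot be ranked. For compound 2, the entry > 10000 nM is a limit of the assay and not a number.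

The next compound is compound 4 `COc1cc(OC)c(-c2coc3cc(OCc4ccc(C(F)(F)F)cc4)ccc3c2=O)cc1OC`, which has 4-(trifluoromethyl)phenyl in place of 3-bromophenyl on a saturated chain carbon bound to an oxygen on an aromatic ring. Among the measured compounds shown here, no measured step makes this exact exchange, so the evidence is indirect. The closest guide is compound 1, which carries 4-bromophenyl and gives 1050 nM. The other two steps, an at least 9.5-fold higher number from compound 1 to compound 2 (0.97 log units; beyond the scatter) and an at least 11-fold lower number from compound 2 to compound 3 (1.06 log units; beyond the scatter), are both beyond the scatter. They show that changing this group can matter greatly in this assay, although both involve 2-cyanophenyl, which compound 4 does not carry. No step beyond the scatter is therefore expected, though a larger rise remains possible. The expected change is a 1.5-fold higher number from compound 3 to compound 4 (0.17 log units; within the scatter). For compound 4 the estimated value is 1300 nM, with an expected range from 450 nM to 5000 nM.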

Compound 4, half-maximal inhibitory concentration: 890 nM
Compound 4: the middle estimate sits 1.5-fold (0.16 log units) above what was measured; low and high end bracket the measured number.
By their numbers in this assay, from the lowest: compounds 3, 4 and 1 (each within the scatter of the next). At a limit, above all of these: compound 2.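

Trifluoromethyl in place of bromo on an aromatic carbon gives a 1.2-fold lower number from compound 1 to compound 4 (0.07 log units; within the scatter), and the exchange of 3-bromophenyl for 4-(trifluoromethyl)phenyl gives a 1.0-fold higher number from compound 3 to compound 4 (0.01 log units; within the scatter), so in this assay compounds 1, 3 and 4 cannot be ranked, and this position accepts a group other than bromophenyl without a step beyond the scatter. The new compound also sharpens the contrast with the nitrile-bearing group, as 4-(trifluoromethyl)phenyl in place of 2-cyanophenyl gives an at least 11-fold lower number from compound 2 to compound 4 (1.05 log units; beyond the scatter), so compound 2 is now the only one of the four set apart. The entry for compound 2 is a limit of the assay and not a number: the limit of > 10000 nM in this assay, at which 1 of the 4 values shown sits.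

As far as these compounds go, it remains open whether the nitrile itself or its place on the ring sets compound 2 apart, and the size of the step to compound 4 cannot say which. From the compounds shown here alone, it is also open whether a phenyl ring carrying an amine or a carboxylic acid on this same chain carbon would stay with compounds 1, 3 and 4 or fall with compound 2.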